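A few compounds are considered here, and "the series" means these few. Any claim that something is new, unique, unknown or untested is made for them only; others in the source may bear on it.

Within the data shown here, compound 2 `COC[C@@H](C1CC1)n1cc(Cl)nc(Nc2c(C)nc(OC)nc2OC)c1=O` holds the lowest number of the two measured so far in an assay on frontal cortex for displacement of a labelled ligand from corticotropin-releasing factor receptor 1 (Rattus norvegicus) (a higher number here means a weaker inhibitor, a lower number a stronger inhibitor), where compound 2 gives 31 nM. Its nearest neighbour is compound 1 `COc1nc(C)c(Nc2nc(Cl)cn([C@H](C)C3CC3)c2=O)c(OC)n1`, which in this assay gives 240 nM; the step of a 7.7-fold lower number from compound 1 to compound 2 (0.89 log units; beyond the scatter) came from placing 1-cyclopropyl-2-methoxyethyl in place of 1-cyclopropylethyl on an aromatic nitrogen. Compound 3 `COC[C@H](C1CC1)n1cc(Cl)nc(Nc2c(C)nc(OC)nc2OC)c1=O` differs from compound 2 in another way: the two compounds have the same atoms and bonds and differ only in configuration as drawn: 1 of 1 stereo elements differ; a stereocentre at a saturated chain carbon is drawn R in compound 2 and S in compound 3. Among the measured compounds shown here, no measured step bears on a change of configuration alone, so the one measured step gives no direct guide, and the direction of the step from compound 2 to compound 3 is open. Since a single stereocentre is inverted, the estimate is that the step of a 4.8-fold higher number from compound 2 to compound 3 (0.68 log units; beyond the scatter) goes toward a weaker number, with a wide range. Compound 3 is expected to give 150 nM, between 25 nM and 900 nM.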

Compound 3, half-maximal inhibitory concentration: 90 nM
The estimate for compound 3 lay 1.7-fold (0.22 log units) above the measured number; the measured number falls inside the stated range.
By their numbers in this assay, from the lowest: compound 2; then compound 3; then compound 1.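

In this assay, the configuration at this saturated chain carbon matters on its own: its inversion gives a 2.9-fold higher number from compound 2 to compound 3 (0.46 log units; beyond the scatter) and leaves the rest of the structure unchanged. The gain from the methoxy group survives this inversion in reduced form, as the step to the S-drawn compound is a 2.7-fold lower number from compound 1 to compound 3 (0.43 log units; beyond the scatter) and remains beyond the scatter, while the step to the R-drawn compound is a 7.7-fold lower number from compound 1 to compound 2 (0.89 log units; beyond the scatter) in the same direction. The gap in this pair can therefore be traced to the stereocentre alone: the fact that compounds 2 and 3 differ only in the configuration as drawn.

On these data alone, it remains open whether the R-drawn form would keep its advantage if the methoxy group gave way to a hydroxyl, an amine or a longer ethoxy chain. As far as these compounds go, how the opposite configuration of the 1-cyclopropylethyl group in compound 1 would stand is also open.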